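The compounds below may be only part of what the source reports. "The series", "measured", "known", "first", "only" and "open" are said of these compounds alone.

Measured compounds:
- compound 1, `CCCCCCCCCCCCCCCCCCNC(=O)[C@@H](NC(=O)c1cc2ccccc2[nH]1)[C@@H](C)O`, 35700 nM
- compound 2, `CCCCCCCCCCCCCCCCCCNC(=O)[C@@H](NC(=O)c1cc2ccccc2n1C)[C@@H](C)O`, 36400 nM

Compound 1 and compound 2 share a long saturated chain on one amide and differ only on the aromatic nitrogen of the core. In a functional assay on MCF7 cells (Homo sapiens) for cytotoxicity, read by MTT assay, with a stated time of 48 h (a higher number here means a weaker inhibitor, a lower number a stronger inhibitor), compound 1 gives 35700 nM, and compound 2 gives 36400 nM. For the measured compounds named here, the one step between them, a 1.0-fold higher number from compound 1 to compound 2 (0.01 log units; within the scatter), is within the scatter, so compound 2 stands at the higher of the two numbers only nominally; the two values are indistinguishable.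

Compound 3, `CCCCCCCCCCCCCCCCCCNC(=O)[C@@H](NS(=O)(=O)c1ccc(C)cc1)[C@@H](C)O`, is the next compound, not yet measured. It differs from compound 2 by (4-methylphenyl)sulfonyl in place of (1-methyl-1H-indol-2-yl)carbonyl on an amine nitrogen. Going by the values given here, no measured step bears on this change: the only step available concerns methyl in place of hydrogen on an aromatic nitrogen and was within the scatter, and it says nothing about exchanging the whole acyl group for a sulfonyl group. The expectation for compound 3 therefore rests on the two weak numbers alone and carries a wide range; the step expected is a 1.1-fold higher number from compound 2 to compound 3 (0.04 log units; within the scatter), with no direction claimed beyond the scatter. For compound 3 the estimate in this assay is 40000 nM, between 10000 nM and 160000 nM.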

Compound 3, half-maximal inhibitory concentration: 60100 nM
Beside the measured number, compound 3's estimate is 1.5-fold (0.18 log units) below it; the range from low to high includes it.
By their numbers in this assay, from the lowest: compounds 1, 2 and 3 (each within the scatter of the next).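

In this assay the amine nitrogen takes a sulfonyl group in place of the whole acyl group without the number leaving the scatter: (4-methylphenyl)sulfonyl in place of (1-methyl-1H-indol-2-yl)carbonyl gives a 1.7-fold higher number from compound 2 to compound 3 (0.22 log units; within the scatter) and, in place of (1H-indol-2-yl)carbonyl, gives a 1.7-fold higher number from compound 1 to compound 3 (0.23 log units; within the scatter) as well. The earlier step covered only methyl in place of hydrogen on an aromatic nitrogen, whereas these two steps remove the carbonyl and the five-membered aromatic ring together, and compounds 1, 2 and 3 still cannot be told apart in this read-out. Nothing at hand explains this result.

From the compounds shown here alone, whether the number moves beyond the scatter when the long saturated chain gives way to a shorter chain, or when an amine or a carboxylic acid stands in place of the methyl of the (4-methylphenyl)sulfonyl group, remains open. With all three values within the scatter of one another, the compounds shown also do not tell which part of the structure, if any, this read-out depends on.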